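A few compounds are considered here, and "the series" means these few. Any claim that something is new, unique, unknown or untested is made for them only; others in the source may bear on it.

In a functional assay on MDA-MB-231 cells (Homo sapiens) for inhibition, read by MTT assay and WST assay, with a stated time of 72 h, tested at 10 uM (a higher number here means more inhibition of growth at the concentration tested, a lower number less inhibition of growth), compound 3 `O=C(Nc1ccc(Oc2ccc(-c3ncc[nH]3)cc2)cc1)Nc1ccc(F)c(C(F)(F)F)c1` gives 26.6%, the lowest of the three numbers shown. Compound 2 `O=C(Nc1ccc(Cl)cc1)Nc1ccc(Oc2ccc(-c3ncc[nH]3)cc2)cc1` gives 47.6% and compound 1 `O=C(Nc1ccc(Oc2ccc(-c3nccs3)cc2)cc1)Nc1cc(Br)cc(C(F)(F)F)c1` gives 72.8%. Within the data shown here, the one measured step touching the same position is a number 21 percentage points lower from compound 2 to compound 3 (beyond the scatter), which shows that the aryl group on this urea nitrogen can shift the result beyond the scatter. Among the measured compounds shown here, compound 4 `O=C(Nc1ccc(Oc2ccc(-c3ncc[nH]3)cc2)cc1)Nc1cc(Br)cc(C(F)(F)F)c1` differs from compound 3 by 3-bromo-5-(trifluoromethyl)phenyl in place of 4-fluoro-3-(trifluoromethyl)phenyl on an amide-type nitrogen; the group that enters is the one compound 1 carries, and compound 1 gives 72.8%. For the measured compounds named here, no measured pair isolates this exchange, so its size is uncertain, but an increase is expected: a number 23.4 percentage points higher from compound 3 to compound 4 (beyond the scatter). Compound 4 is therefore estimated at 50%, within 30% to 72%.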

Compound 4, percent growth inhibition at one concentration: -13.6%
The estimate for compound 4 lay 63.6 percentage points above the measured number, and the stated range ends above it.
By their numbers in this assay, from the lowest: compound 4; then compound 3; then compound 2; then compound 1.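

In this assay the 3-bromo-5-(trifluoromethyl)phenyl group on the amide-type nitrogen brought no gain with 1H-imidazol-2-yl in the core: the exchanges gave a number 40.2 percentage points lower from compound 3 to compound 4 (beyond the scatter) and a number 61.2 percentage points lower from compound 2 to compound 4 (beyond the scatter) in the same core. The result for this aryl group therefore depended on the other place, with a number 86.4 percentage points lower from compound 1 to compound 4 (beyond the scatter) for 1H-imidazol-2-yl in place of 1,3-thiazol-2-yl on an aromatic carbon. Nothing available accounts for this reversal. Still open, as far as these compounds go, is how 4-chlorophenyl behaves with 1,3-thiazol-2-yl, and whether a pyridin-2-yl group or a carboxylic acid on that aromatic carbon would retain the growth inhibition seen for compound 1.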